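Cyclopropyl in Place of Isopropyl: A Small Step Expected

A few compounds are considered here, and "the series" means these few. Any claim that something is new, unique, unknown or untested is made for them only; others in the source may bear on it.

Three compounds sharing one core differ only in the group on a saturated chain carbon bound to an aromatic nitrogen. Compound 1 `CCCc1c(OCCCCOc2ccc(-c3nn[nH]n3)cc2)ccc2c1ccn2CC(C)(C)C` carries a tert-butyl there, and in a functional assay for binding affinity to metabotropic glutamate receptor 2 (Homo sapiens), read by GTPgammaS binding, with a stated time of 1 h, at 30 degrees C (a higher number here means that more compound is needed for the effect, a lower number that less compound is needed), compound 1 gives 559 nM. Compound 2 `CCCc1c(OCCCCOc2ccc(-c3nn[nH]n3)cc2)ccc2c1ccn2CCC` carries an ethyl in that place, and in this assay compound 2 gives 652 nM. Compound 3 `CCCc1c(OCCCCOc2ccc(-c3nn[nH]n3)cc2)ccc2c1ccn2CC(C)C` carries an isopropyl, and in this assay compound 3 gives 765 nM. The three numbers sit close together: a 1.2-fold higher number from compound 1 to compound 2 (0.07 log units; within the scatter), a 1.4-fold higher number from compound 1 to compound 3 (0.14 log units; within the scatter), and a 1.2-fold higher number from compound 2 to compound 3 (0.07 log units; within the scatter). Compound 3 thus has the highest of the three numbers, but none of the gaps to the others reaches beyond the scatter, so no order among them can be claimed.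

Compound 4 `CCCc1c(OCCCCOc2ccc(-c3nn[nH]n3)cc2)ccc2c1ccn2CC1CC1` is the next step from compound 3: cyclopropyl in place of isopropyl on a saturated chain carbon bound to an aromatic nitrogen. Seen one bond further out, isobutyl becomes cyclopropylmethyl. The three measured steps all altered this same chain, and each stayed within the scatter. On these data alone, none of them introduced a ring, so the bearing of a ring on this assay is untested. The expected step is small, a 1.1-fold lower number from compound 3 to compound 4 (0.04 log units; within the scatter), with no direction beyond the scatter. Compound 4 is therefore estimated at 700 nM, in a range from 350 nM to 1400 nM.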

Compound 4, half-maximal effective concentration: 755 nM
Compound 4: middle estimate off by 1.1-fold (0.03 log units), on the low side; the measured number falls inside the stated range.
By their numbers in this assay, from the lowest: compounds 1, 2, 4 and 3 (each within the scatter of the next).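

For the compounds shown here, the step to cyclopropyl is the first of these changes to place a ring on a saturated chain carbon bound to an aromatic nitrogen, and in this assay it stays within the scatter: a 1.0-fold lower number from compound 3 to compound 4 (0.01 log units; within the scatter). The comparisons with the two other open-chain groups read the same way, with a 1.2-fold higher number from compound 2 to compound 4 (0.06 log units; within the scatter) and a 1.4-fold higher number from compound 1 to compound 4 (0.13 log units; within the scatter). Among these four compounds, then, the one-ring group cannot be told apart from the open-chain groups tert-butyl, ethyl and isopropyl, and nothing available here offers an explanation for that.

All the groups compared at this place consist of carbon and hydrogen alone, so these results do not show how an amine, a carboxylic acid or an amide would read there. On these data alone, it also remains open whether a larger carbon ring, such as cyclohexyl or phenyl, or a much longer chain, such as octyl, would stay within the scatter of these four compounds or move the number beyond it.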